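The source may report more compounds than this note shows. Statements on the series, on what has been measured and on what is new or still open speak of the compounds shown alone.

Compound 1, `COc1ccc(C(=O)/C(=C/C2CCCCC2)COC(C)=O)cc1`, gives 90000 nM.
Compound 2, `COc1ccc(C(=O)/C(=C/C2CCCCC2)COC(=O)c2ccccc2)cc1`, gives 36000 nM.
Compound 3, `C=C(C(=O)c1ccc(OC)cc1)C(OC(C)=O)c1ccccc1F`, gives 67300 nM.

All three were tested in a functional assay on A549 cells (Homo sapiens) for inhibition, read by XTT assay, with a stated time of 48 h; a higher number here means a weaker inhibitor, a lower number a stronger inhibitor. Compound 1 and compound 2 share a core and differ in a single place: phenyl in place of methyl on a carbonyl carbon. That one change produced a 2.5-fold lower number from compound 1 to compound 2 (0.40 log units; beyond the scatter). Compound 3 is built on a different core; how its core differs from the core of compound 1 is not broken down here. In this assay the value of compound 3 sits close to that of compound 1, within the usual scatter of repeated measurements, so the two cannot be told apart on these numbers.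

Compound 4, `C=C(C(=O)c1ccc(OC)cc1)C(OC(=O)c1ccccc1)c1ccccc1F`, has not yet been measured in this assay. It differs from compound 3 in exactly the way compound 2 differs from compound 1: phenyl in place of methyl on a carbonyl carbon. The surroundings of the changed position read the same in both pairs, so this is the same change, made once on each core. Among the compounds with values here, the only guide to its effect is the single measured pair, and one pair cannot show whether the change behaves alike on the core of compound 3. With that caution, the expected step is a 2.5-fold lower number from compound 3 to compound 4 (0.40 log units; beyond the scatter), about the size of a 2.5-fold lower number from compound 1 to compound 2 (0.40 log units; beyond the scatter). Compound 4 is therefore estimated at 27000 nM in this assay. For compound 4 the number is expected to fall between 12000 nM and 60000 nM.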

Compound 4, half-maximal inhibitory concentration: 73700 nM
Beside the measured number, compound 4's estimate is 2.7-fold (0.44 log units) below it; the whole stated range lies below it.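

In this assay, replacing acetoxy with benzoyloxy gave a 1.1-fold higher number from compound 3 to compound 4 (0.04 log units; within the scatter), so on this core the swap from methyl to phenyl on the carbonyl carbon produced no change that can be told from ordinary assay noise. Within the data shown here, with only two pairs, the result cannot show which feature of the two cores separates the outcomes, nor whether the same split would appear on any further core, and it says nothing about why the cores behave differently. It does show that the modest gain seen on the core of compound 1 did not carry over to the core of compound 3, so a step measured on one core in this series is not a safe forecast for the other: the same change on two cores in this assay, a 2.5-fold lower number (0.40 log units; beyond the scatter) from compound 1 to compound 2 and a 1.1-fold higher number (0.04 log units; within the scatter) from compound 3 to compound 4, 2.7-fold (0.44 log units) apart, beyond the scatter of two such steps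

The compounds shown place only methyl and phenyl on this carbonyl carbon, so it remains open how a longer chain such as butyl, or an amine at the same carbon, would behave on either core. As far as these compounds go, it also remains open whether a substituted phenyl, such as one bearing a methoxy group, would separate the two cores in the same way or bring them back together.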